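From Chloro to Fluoro on the Aromatic Ring

This account rests on a few compounds, and the source may have more. Where it says the series, first, only, none or still open, it means among the compounds named here.

Measured in a functional assay (plasma) for inhibition, with Homo sapiens as the target; on this read-out lower numbers stand for stronger inhibition and higher numbers for weaker inhibition:
Compound 1 `Cc1ccc(S(=O)(=O)N[C@H]2CC[C@H](O)[C@@H]2C/C=C\CCC(=O)O)cc1`: 2500 nM
Compound 2 `O=C(O)CCC/C=C\C[C@@H]1[C@@H](NS(=O)(=O)c2ccc(F)cc2)CC[C@@H]1O`: 640 nM
Compound 3 `O=C(O)CC/C=C\C[C@@H]1[C@@H](NS(=O)(=O)c2ccc(Cl)cc2)CC[C@@H]1O`: 1800 nM

Compound 3, at 1800 nM, lies within the scatter of compound 1 and clearly above compound 2. Compound 4 `O=C(O)CC/C=C\C[C@@H]1[C@@H](NS(=O)(=O)c2ccc(F)cc2)CC[C@@H]1O` has not been measured yet. It differs from compound 3 in a single atom: fluoro in place of chloro on an aromatic carbon. In words, this is fluoro in place of chloro on an aromatic carbon, para to a large group, so 4-chlorophenyl becomes 4-fluorophenyl.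

One measured step changes a group on an aromatic carbon in the same way: a 1.4-fold lower number from compound 1 to compound 3 (0.14 log units; within the scatter), with chloro in place of methyl. That step is small, but a single step is thin evidence. Compound 2 also carries 4-fluorophenyl and gives a lower number than compound 3, but its acid chain differs in length from that of compound 4. The data cannot show which of the two differences between compound 2 and compound 3 accounts for that gap.

No step beyond the scatter is therefore expected in this assay, with only a small lean towards compound 2 at 640 nM. The expected step is a 1.3-fold lower number from compound 3 to compound 4 (0.11 log units; within the scatter). For compound 4 the estimate is 1400 nM, with an expected range from 600 nM to 3500 nM.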

Compound 4, half-maximal inhibitory concentration: 1600 nM
Estimate against measurement, compound 4: 1.1-fold (0.06 log units) below; low and high end bracket the measured number.
By their numbers in this assay, from the lowest: compound 2; then compounds 4, 3 and 1 (each within the scatter of the next).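

In this assay, going by these compounds alone, a 1.1-fold lower number from compound 3 to compound 4 (0.05 log units; within the scatter) shows that exchanging chloro for fluoro on this aromatic carbon, para to a large group, gives no step that can be told from the scatter. With a 1.6-fold lower number from compound 1 to compound 4 (0.19 log units; within the scatter) added, methyl, chloro and fluoro at this place all lie within the scatter of one another on the acid chain shared by compound 1, compound 3 and compound 4. The 4-fluorophenyl group alone therefore does not give the low number of compound 2, for a 2.5-fold higher number from compound 2 to compound 4 (0.40 log units; beyond the scatter) is a step beyond the scatter between two compounds that carry that same group and differ only in the chain, with carboxy in place of carboxymethyl.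

No measurement here offers an explanation for any of these numbers. As far as these compounds go, it remains open whether a larger group at the same place, such as trifluoromethyl or methoxy, would give a step beyond the scatter, and whether methyl or chloro on the chain of compound 2 would give a number close to that of compound 2.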